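Replacing 2-fluorophenyl with 4-acetylphenyl: an expected antiproliferative step

The compounds below may be only part of what the source reports. "The series", "measured", "known", "first", "only" and "open" are said of these compounds alone.

In a functional assay on HeLa cells (Homo sapiens) for antiproliferative activity, read by MTT assay, with a stated time of 72 h (a lower number here means a stronger inhibitor, a higher number a weaker inhibitor), compound 1 `Nc1nc(N)c2cc(CSC(=S)N3CCN(c4ccc(O)cc4)CC3)ccc2n1` reads 5180 nM on the scale, compound 2 `Cc1ccc(N2CCN(C(=S)SCc3ccc4nc(N)nc(N)c4c3)CC2)cc1` reads 2130 nM and compound 3 `Nc1nc(N)c2cc(CSC(=S)N3CCN(c4ccccc4F)CC3)ccc2n1` reads 6660 nM on the same scale. Compound 3 stands at the weak end of this small set together with compound 1. The data show a 1.3-fold higher number from compound 1 to compound 3 (0.11 log units; within the scatter) for that pair, against a 3.1-fold higher number from compound 2 to compound 3 (0.50 log units; beyond the scatter) on the other side.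

The next structure is compound 4 `CC(=O)c1ccc(N2CCN(C(=S)SCc3ccc4nc(N)nc(N)c4c3)CC2)cc1`, with 4-acetylphenyl in place of 2-fluorophenyl on an amine nitrogen in a ring, a change counted as 4-acetylphenyl in place of 2-fluorophenyl on an amine nitrogen in a ring in full. The steps at this same place bear on it, and neither of them is more than modest. Alongside them stands a 2.4-fold lower number from compound 1 to compound 2 (0.39 log units; beyond the scatter) between the 4-hydroxyphenyl and 4-methylphenyl groups. These steps give no ground for a large shift, so a small move to a lower number is expected, with no change beyond the scatter also possible. The estimated step is a 1.9-fold lower number from compound 3 to compound 4 (0.28 log units; within the scatter) in this assay for this change. Compound 4 is estimated at 3500 nM with a range from 1300 nM to 9000 nM as its expected span.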

Compound 4, half-maximal inhibitory concentration: 2040 nM
Beside the measured number, compound 4's estimate is 1.7-fold (0.23 log units) above it; low and high end bracket the measured number.
By their numbers in this assay, from the lowest: compounds 4 and 2 (each within the scatter of the next); then compounds 1 and 3 (each within the scatter of the next).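

In this assay, the 4-acetylphenyl group brings a 3.3-fold lower number from compound 3 to compound 4 (0.51 log units; beyond the scatter), a modest gain over 2-fluorophenyl at this ring nitrogen. The carbonyl-bearing acetyl group and the methyl group cannot be told apart, with a 1.0-fold lower number from compound 2 to compound 4 (0.02 log units; within the scatter), whereas acetyl in place of hydroxy gives a 2.5-fold lower number from compound 1 to compound 4 (0.40 log units; beyond the scatter), so among the four compounds the 4-acetylphenyl and 4-methylphenyl groups sit at the low end while 4-hydroxyphenyl and 2-fluorophenyl sit at the high end. Nothing in the data explains this grouping.

As far as these compounds go, how a 4-fluorophenyl group would read remains open, so the effect of the fluorine cannot be separated from that of its place on the ring. Also open, from the compounds shown here alone, is whether an amine or a carboxylic acid on that aromatic carbon would fall with the methyl and acetyl compounds or with the hydroxy compound.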